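This account rests on a few compounds, and the source may have more. Where it says the series, first, only, none or still open, it means among the compounds named here.

Compound 1 `COc1ccc(-c2cc(/C=C/C(=O)c3ccc(N)cc3)[nH]n2)cc1`: -74%
Compound 2 `COc1cc(-c2cc(/C=C/C(=O)c3ccc(N)cc3)[nH]n2)cc(OC)c1OC`: -78%
Compound 3 `COc1ccc(C(=O)/C=C/c2cc(-c3cc(OC)c(OC)c(OC)c3)n[nH]2)cc1OC`: -75%

In a functional assay on COLO 205 cells (Homo sapiens) for cytotoxicity, read by sulforhodamine B assay, with a stated time of 48 h, tested at 100 uM (a higher number here means a weaker effect of the compound at the concentration tested, a lower number a stronger effect), compound 2 gives -78%, the lowest of the three numbers, yet compound 3 with -75% and compound 1 with -74% both sit within the scatter of it, so no order among the three can be read. Among the compounds with values here, the single step measured between neighbours, a number 3 percentage points higher from compound 2 to compound 3 (within the scatter), is within the scatter as well.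

Compound 4 `COc1ccc(-c2cc(/C=C/C(=O)c3ccc(N)cc3)[nH]n2)cc1OC` differs from compound 2 in one place: hydrogen in place of methoxy on an aromatic carbon. Within the data shown here, no measured step removes a methoxy group from that six-membered aromatic ring of carbon only; the only measured step, a number 3 percentage points higher from compound 2 to compound 3 (within the scatter), exchanges the group on the carbonyl carbon and bears on this change only loosely. Compound 1 shows -74% and compound 2 shows -78%, two numbers within the scatter although their methoxy groups on that ring differ, which argues against a large effect of such groups here. The step of a number 3 percentage points higher from compound 2 to compound 4 (within the scatter) is therefore expected to stay within the scatter. Compound 4 is estimated at -75%, with a range from -88% to -58%.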

Compound 4, a percentage reported as activity, at one concentration (the size of the read-out at that concentration, not a potency): -78%
The estimate for compound 4 lay 3 percentage points above the measured number, within the range that was stated.
By their numbers in this assay, from the lowest: compounds 2, 4, 3 and 1 (each within the scatter of the next).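

Two steps now bear directly on methoxy groups of this six-membered aromatic ring in this assay: hydrogen in place of methoxy gives no change at the digits printed from compound 2 to compound 4 (within the scatter), and methoxy in place of hydrogen gives a number 4 percentage points lower from compound 1 to compound 4 (within the scatter). Within the data shown here, earlier, the only measured step lay on the carbonyl carbon, whereas these two show directly that exchanging methoxy and hydrogen on this ring stays within the scatter for these pairs. Nothing at hand offers an explanation for this result.

Going by these compounds, whether a hydroxyl group or a fluorine atom on this aromatic carbon would give a number beyond the scatter remains open. Also open, on these data alone, is whether these compounds would separate at a lower concentration, as a read-out at one concentration is not a potency.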